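Swapping a Methoxypyridine for an Indole in Liver Microsomes

This account rests on a few compounds, and the source may have more. Where it says the series, first, only, none or still open, it means among the compounds named here.

Compound 1 `Nc1ccc(S(=O)(=O)N2CCN(c3ncc(C(O)(C(F)(F)F)C(F)(F)F)cc3-c3ccoc3)CC2)cn1`: < 14 mL.min-1.g-1
Compound 2 `Cc1ccc(-c2cc(C(O)(C(F)(F)F)C(F)(F)F)cnc2N2CCN(S(=O)(=O)c3ccc(N)nc3)CC2)cn1`: 43 mL.min-1.g-1
Compound 3 `COc1ccc(-c2cc(C(O)(C(F)(F)F)C(F)(F)F)cnc2N2CCN(S(=O)(=O)c3ccc(N)nc3)CC2)cn1`: 25 mL.min-1.g-1

These values come from an ADME assay (liver) for metabolic stability, with Liver microsome (Homo sapiens) as the target, using microsomes and NADPH, with a stated time of 30 min, tested at 1 uM; a higher number here means faster removal of the compound, a lower number slower removal. The value of compound 1 is a limit of this assay, not a number. Among the numbers shown, compound 3 stands lowest, with compound 2 nearest: a 1.7-fold lower number from compound 2 to compound 3 (0.24 log units; within the scatter). The unmeasured compound 4 `Nc1ccc(S(=O)(=O)N2CCN(c3ncc(C(O)(C(F)(F)F)C(F)(F)F)cc3-c3cc4ccccc4[nH]3)CC2)cn1` differs from compound 3 in one place: 1H-indol-2-yl in place of 6-methoxypyridin-3-yl on an aromatic carbon. Among the measured compounds shown here, no measured step exchanges this group; the closest guidance is an at least 1.7-fold higher number from compound 1 to compound 3 (0.25 log units; that floor lies within the scatter) and an at least 3.0-fold higher number from compound 1 to compound 2 (0.48 log units; beyond the scatter), both replacements of furan-3-yl that gave higher numbers. For compound 4 a similar modest rise is therefore expected in this assay: a 1.6-fold higher number from compound 3 to compound 4 (0.20 log units; within the scatter). Compound 4 is estimated at 40 mL.min-1.g-1, most likely between 18 mL.min-1.g-1 and 90 mL.min-1.g-1.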

Compound 4, intrinsic clearance in microsomes: < 14 mL.min-1.g-1
Compound 4: a limit, no number; the forecaster's own chance of this, stated with the estimate: 5%; middle value at least 2.8-fold (0.45 log units) from the limit.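

Compound 4 gives < 14 mL.min-1.g-1 in this assay, which is a limit of the assay and not a number. The 1H-indol-2-yl group does not keep the higher numbers seen with the two pyridines at this place: the change gives an at least 3.0-fold lower number from compound 2 to compound 4 (0.48 log units; beyond the scatter), and an at least 1.7-fold lower number from compound 3 to compound 4 (0.25 log units; that floor lies within the scatter). The step between compound 1 and compound 4 cannot be read because both sit at the same limit: the limit of < 14 mL.min-1.g-1 in this assay, at which 2 of the 4 values shown sit.

Going by these compounds, the actual values of compound 1 and compound 4 stay open. Also open, on these data alone, is whether a methyl group on the indole nitrogen would leave compound 4 at this limit.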